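The compounds below may be only part of what the source reports. "The series", "measured", "known", "first", "only" and "open" are said of these compounds alone.

Series notes, this assay.

Compound 1 `O=C(/C=C/c1ccc(F)cc1)NS(=O)(=O)c1ccc(Br)cc1` gives 2.8 ug/mL.
Compound 2 `O=C(/C=C/c1ccc(Br)cc1)NS(=O)(=O)c1ccccc1` gives 3.9 ug/mL.
Compound 3 `O=C(/C=C/c1ccc(Br)cc1)NS(=O)(=O)c1ccc(Br)cc1` gives 5.1 ug/mL.

In a functional assay on B16-F10 cells (Mus musculus) for antiproliferative activity, read by ELISA and MTT assay, with a stated time of 48 h (a lower number here means a stronger inhibitor, a higher number a weaker inhibitor), compound 3 stands at the highest of the three numbers, yet both of its neighbours lie within the scatter of it: a 1.8-fold higher number from compound 1 to compound 3 (0.26 log units; within the scatter) and a 1.3-fold higher number from compound 2 to compound 3 (0.12 log units; within the scatter). The three values therefore show no separation beyond the usual spread.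

Compound 4 `CN(C)c1ccc(/C=C/C(=O)NS(=O)(=O)c2ccc(Br)cc2)cc1` differs from compound 3 by dimethylamino in place of bromo on an aromatic carbon. Neither measured step involves a dimethylamino group; both concern an exchange among halogen or hydrogen on an aromatic carbon, and both stayed within the scatter. No step beyond the scatter is expected here, with a wide range to reflect the untested group.

Compound 4 is expected to give about 4 ug/mL (range 1.5 ug/mL to 10 ug/mL), an estimated step of a 1.3-fold lower number from compound 3 to compound 4 (0.11 log units; within the scatter).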

Compound 4, half-maximal inhibitory concentration: 4.2 ug/mL
The estimate for compound 4 lay 1.1-fold (0.02 log units) below the measured number; the range from low to high includes it.
By their numbers in this assay, from the lowest: compounds 1, 2, 4 and 3 (each within the scatter of the next).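

Dimethylamino in place of bromo gives a 1.2-fold lower number from compound 3 to compound 4 (0.08 log units; within the scatter) in this assay and dimethylamino in place of fluoro gives a 1.5-fold higher number from compound 1 to compound 4 (0.18 log units; within the scatter) at this position. These steps extend the earlier exchanges among halogen and hydrogen to a nitrogen-bearing group with 3 heavy atoms and 1 hydrogen-bond acceptor, and the result still stays within the scatter. No measurement shown bears on what lies behind these small steps.

On these data alone, whether a carboxylic acid, a nitro group or a longer chain on this aromatic carbon would move the number beyond the scatter remains open.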